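A few compounds are considered here, and "the series" means these few. Any claim that something is new, unique, unknown or untested is made for them only; others in the source may bear on it.

Working notes on the series. Compound 1 `CNc1cc(-n2nc(C(C)C)c3c(-n4cnc(-c5cnn(C)c5)c4)ccnc32)ccc1C(N)=O` stands at the top of the three numbers in hand: in a functional assay on SK-BR-3 cells (Homo sapiens) for inhibition, read by CellTiter-Glo, with a stated time of 72 h (a lower number here means a stronger inhibitor, a higher number a weaker inhibitor), compound 1 gives 773 nM, and its gaps to both other measured compounds lie beyond the scatter. Compound 2 `CC(C)c1nn(-c2ccc(C(N)=O)c(N[C@H]3CC[C@H](O)CC3)c2)c2nccc(-n3cnc(-c4ccncc4)c3)c12` gives 165 nM in this assay, and compound 3 `CC(C)c1nn(-c2ccc(C(N)=O)c(N[C@H]3CC[C@H](O)CC3)c2)c2cccc(-c3cnc4ccccc4c3)c12` gives 39 nM. Among the compounds with values here, compound 2 and compound 3 differ from compound 1 in more than one place, so no single-change step between measured compounds is available, and nothing in the measured set isolates the effect of moving a group around the phenyl on the aromatic nitrogen.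

Compound 4 `CNc1cc(C(N)=O)ccc1-n1nc(C(C)C)c2c(-n3cnc(-c4cnn(C)c4)c3)ccnc21` is built from the same atoms as compound 1, joined differently: 4-carbamoyl-2-(methylamino)phenyl in place of 4-carbamoyl-3-(methylamino)phenyl on an aromatic nitrogen. Within the data shown here, with no measured step of this kind to lean on, the direction of the change is open; the expectation is a step of modest size, somewhat more likely toward a higher number than toward a lower one, and not far beyond the scatter. For compound 4 the expected step from compound 1 is a 1.9-fold higher number from compound 1 to compound 4 (0.29 log units; within the scatter). The estimate for compound 4 in this assay is 1500 nM, with a range from 350 nM to 6500 nM.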

Compound 4, half-maximal inhibitory concentration in the SK-BR-3 assay: 419 nM
Compound 4: the middle estimate sits 3.6-fold (0.55 log units) above what was measured; the range from low to high includes it.
By their numbers in the SK-BR-3 assay, from the lowest: compound 3; then compound 2; then compounds 4 and 1 (each within the scatter of the next).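

The change from 4-carbamoyl-3-(methylamino)phenyl to 4-carbamoyl-2-(methylamino)phenyl on the aromatic nitrogen gives the series its first single-change step, and in the SK-BR-3 assay that step is small: a 1.8-fold lower number from compound 1 to compound 4 (0.27 log units; within the scatter). The same atoms, joined differently at this place, therefore leave compound 1 and compound 4 unseparated by the cell read-out. In a physicochemical assay for lipophilicity, read by HPLC, measured as octanol-water partition, at pH 7.4 (a higher number here means a more lipophilic compound, a lower number a more polar compound), compound 1 gives 3 and compound 4 gives 1.9, so this position moves lipophilicity well beyond the scatter while the SK-BR-3 assay stays within it, and compound 4 is the less lipophilic of the pair at no cost that the cell read-out can detect: the measured distribution coefficient of compound 1, 3, and of compound 4, 1.9, a number 1.10 log units lower (beyond the scatter).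

On these data alone, whether this pattern holds for other groups at this position remains open, for instance a dimethylamino group or a methoxy group in place of the methylamino group, or a nitrile in place of the carbamoyl group. As far as these compounds go, compound 2 and compound 3 differ from compound 4 in more than one place, so it also remains open whether the same change would act alike on the cores and side chains they carry.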